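The source may report more compounds than this note shows. Statements on the series, on what has been measured and on what is new or still open speak of the compounds shown alone.

Working notes on the series. Three measured entries share one core: compound 1 `Oc1ccc(-c2cc(-c3ccccn3)nc(-c3ccccc3Cl)c2)cc1`, compound 2 `Oc1ccc(-c2cc(-c3ccco3)nc(-c3ccccc3Cl)c2)cc1` and compound 3 `Oc1ccc(-c2cc(-c3ccncc3)nc(-c3ccccc3Cl)c2)cc1`. In an ADME assay on HEK293 cells (Homo sapiens) for cytotoxicity, read by CCK-8 assay and cell counting, with a stated time of 2 days (on this read-out higher numbers stand for weaker inhibition and lower numbers for stronger inhibition), only compound 2 gives a number, 4310 nM. Within the data shown here, for compound 1 the entry in this assay reads "not determined" (no result reported), and for compound 3 it reads "not determined" (no result reported), so compound 2 stands alone as the single reference point and no step between measured compounds can be drawn.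

Compound 4 `Oc1ccc(-c2cc(-c3cccc(Cl)c3)nc(-c3ccco3)c2)cc1` is still to be measured in this assay. Against compound 2 the difference is 3-chlorophenyl in place of 2-chlorophenyl on an aromatic carbon, the same atoms joined differently. Among the measured compounds shown here, with no measured step of this kind to lean on, the expectation rests on compound 2 alone, whose 4310 nM is the only anchor. Moving the chlorine around the same ring is taken as a step of no clear direction, likely within the usual scatter, so compound 4 is expected to land at 4300 nM in this assay, with a range from 1500 nM to 12000 nM, the estimated step from compound 2 to compound 4 being a 1.0-fold lower number from compound 2 to compound 4 (0.00 log units; within the scatter).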

Compound 4, half-maximal inhibitory concentration: 2880 nM
The estimate for compound 4 lay 1.5-fold (0.17 log units) above the measured number; the measured number falls inside the stated range.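

Among these compounds, exchanging 2-chlorophenyl for 3-chlorophenyl next to the ring nitrogen gives, in this assay, a 1.5-fold lower number from compound 2 to compound 4 (0.18 log units; within the scatter), the only step so far that can be read. For this one pair, the two chlorine placements on the phenyl ring cannot be told apart on this read-out, and compound 2 no longer stands as the sole reference point. Nothing at hand explains the step or ties it to a property of either group.

Open, going by these compounds, is whether a phenyl ring carrying an amine or a carboxylic acid at this position would read the same as the two chlorophenyl groups. Also open, on these data alone, is whether the step holds with a group other than furan-2-yl on the shared core.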